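The source may report more compounds than this note shows. Statements on the series, on what has been measured and on what is new or still open speak of the compounds shown alone.

Among the measured compounds shown here, in a functional assay on HepG2 cells (Homo sapiens) for cytotoxicity, read by MTT assay (a higher number here means a weaker inhibitor, a lower number a stronger inhibitor), compound 1 `CCCCC(=O)Oc1cc(/C=C/C(=O)c2ccc(OC)c3c2OC(C)(C)C=C3)ccc1OC` gives 100 nM, the lowest of the three numbers measured so far. Compound 2 `COc1ccc(/C=C/C(=O)c2ccc(OC)c3c2OC(C)(C)C=C3)cc1OC(=O)C1CC1` gives 220 nM, and compound 3 `COc1ccc(/C=C/C(=O)c2ccc(OC)c3c2OC(C)(C)C=C3)cc1OC(=O)c1ccco1` gives 370 nM. The unmeasured compound 4 `COc1ccc(/C=C/C(=O)c2ccc(OC)c3c2OC(C)(C)C=C3)cc1OS(=O)(=O)Cc1ccccc1` differs from compound 1 in a single place: benzylsulfonyl in place of butylcarbonyl on an oxygen on an aromatic ring. For the measured compounds named here, two measured steps bear on this, both exchanging the butyl on a carbonyl carbon for something else: a 2.2-fold higher number from compound 1 to compound 2 (0.34 log units; beyond the scatter) and a 3.7-fold higher number from compound 1 to compound 3 (0.57 log units; beyond the scatter), each a modest rise. The change to compound 4 is larger than either, since the whole butylcarbonyl leaves and benzylsulfonyl enters, so a rise of similar or somewhat greater size is expected, a 3.5-fold higher number from compound 1 to compound 4 (0.54 log units; beyond the scatter). In this assay compound 4 is therefore estimated at 350 nM, within a range from 120 nM to 1000 nM.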

Compound 4, half-maximal inhibitory concentration: > 10000 nM
Compound 4: only a limit was reported; the forecaster's own chance of this, stated with the estimate: 5%; at least 28-fold (1.45 log units) between middle value and limit.
By their numbers in this assay, from the lowest: compound 1; then compounds 2 and 3 (each within the scatter of the next). At a limit, above all of these: compound 4.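

In this assay compound 4 reaches only a limit of the assay, not a number: the limit of > 10000 nM in this assay, at which 1 of the 4 values shown sits. Exchanging the group on the carbonyl carbon changed the number modestly at most, but benzylsulfonyl in place of the whole carbonyl-bearing group gives an at least 100-fold higher number from compound 1 to compound 4 (2.00 log units; beyond the scatter), along with an at least 45-fold higher number from compound 2 to compound 4 (1.65 log units; beyond the scatter) and an at least 27-fold higher number from compound 3 to compound 4 (1.43 log units; beyond the scatter). The group on this oxygen can therefore matter far more than the carbonyl compounds alone suggested.

The compounds shown do not separate the effect of the sulfonyl from that of the benzyl. A methylsulfonyl group or a phenylacetyl group on this oxygen would help tell them apart.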